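The compounds below may be only part of what the source reports. "The series", "measured", "known", "first", "only" and "open" are said of these compounds alone.

Measured compounds in a functional assay on MGC-803 cells (Homo sapiens) for cytotoxicity, read by MTT assay, with a stated time of 72 h; on this read-out lower numbers stand for stronger inhibition and higher numbers for weaker inhibition:
Compound 1, `FC(F)(F)c1ccc(CSc2nc(Nc3ccccc3)c3ccccc3n2)cc1`: compound 1 gives 22200 nM
Compound 2, `FC(F)(F)c1ccc(CSc2nc(Nc3cccc(Cl)c3)c3ccccc3n2)cc1`: compound 2 gives 14600 nM
Compound 3, `FC(F)(F)c1ccc(CSc2nc(Nc3cccc(Br)c3)c3ccccc3n2)cc1`: compound 3 gives 23700 nM

Among these three numbers compound 1 stands second highest. Its nearest neighbour is compound 3, with a 1.1-fold higher number from compound 1 to compound 3 (0.03 log units; within the scatter), and its furthest is compound 2, with a 1.5-fold lower number from compound 1 to compound 2 (0.18 log units; within the scatter); both steps lie within the scatter, as does a 1.6-fold higher number from compound 2 to compound 3 (0.21 log units; within the scatter), so the three compounds cannot be told apart on this read-out.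

The unmeasured compound 4, `COc1ccc(Nc2nc(SCc3ccc(C(F)(F)F)cc3)nc3ccccc23)cc1OC`, differs from compound 1 in one place: 3,4-dimethoxyphenyl in place of phenyl on a nitrogen on an aromatic ring. Among the measured compounds shown here, the measured steps that bear on it are the halogen changes on the same anilino ring, which all stayed within the scatter; none of them introduces a methoxy group, so no step on the 3,4-dimethoxyphenyl change itself is available. On this evidence a step of no more than the scatter in this assay is expected, with no clear direction. Compound 4 is therefore estimated at 20000 nM, with a range from 8000 nM to 50000 nM, which corresponds to an expected step of a 1.1-fold lower number from compound 1 to compound 4 (0.05 log units; within the scatter).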

Compound 4, half-maximal inhibitory concentration: 16300 nM
Beside the measured number, compound 4's estimate is 1.2-fold (0.09 log units) above it; low and high end bracket the measured number.
By their numbers in this assay, from the lowest: compounds 2, 4, 1 and 3 (each within the scatter of the next).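

The change from phenyl to 3,4-dimethoxyphenyl on a nitrogen on an aromatic ring is the first shown here that brings oxygen and hydrogen-bond acceptors to this position, and it adds more heavy atoms than either halogen. Even so, this assay records a 1.4-fold lower number from compound 1 to compound 4 (0.13 log units; within the scatter), so this position accepts the two methoxy groups with no change that can be told from the scatter. Set against the halogen-bearing rings, the new group gives a 1.5-fold lower number from compound 3 to compound 4 (0.16 log units; within the scatter) and a 1.1-fold higher number from compound 2 to compound 4 (0.05 log units; within the scatter), so all four anilino variants remain indistinguishable on this read-out, and no measurement is available to account for this flat result.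

The compounds shown leave open whether any group on this ring can move the number beyond the scatter, for instance a primary amine, a carboxylic acid or a longer alkoxy chain. They also leave open whether a single methoxy group would behave as the pair does, and whether changes elsewhere on the shared core would matter more than those on this ring.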